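Dibromocatechol series: cytotoxicity notes on compound 4

A few compounds are considered here, and "the series" means these few. Any claim that something is new, unique, unknown or untested is made for them only; others in the source may bear on it.

Measured so far:
compound 1 `O=Cc1cc(Br)c(O)c(O)c1Br` — 31000 nM in a functional assay on DLD-1 cells (Homo sapiens) for cytotoxicity, read by MTT assay, with a stated time of 96 h; a lower number here means a stronger inhibitor, a higher number a weaker inhibitor
compound 2 `OCc1cc(Br)c(O)c(O)c1Br` — 15000 nM
compound 3 `COCc1cc(O)c(O)c(Br)c1` — 35300 nM

Compound 3 gives the highest of the three numbers in this assay, though its gap to compound 1 is within the scatter; against compound 2 it stands clearly higher. Within the data shown here, the only one-place step measured is a 2.1-fold lower number from compound 1 to compound 2 (0.32 log units; beyond the scatter), a modest change on the group attached to the core.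

Compound 4 `COCc1cc(Br)c(O)c(O)c1Br` differs from compound 3 by bromo in place of hydrogen on an aromatic carbon. Among the measured compounds shown here, no measured step covers the entry of a bromo group, so the step from compound 1 to compound 2 bears on it only indirectly. Compounds 1 and 2, which both carry two bromo groups, show values that are no worse than compound 3 and in the case of compound 2 somewhat better; this is all the comparison the data allow.

The estimate for compound 4 is therefore a small step downward, a 1.5-fold lower number from compound 3 to compound 4 (0.17 log units; within the scatter), with considerable uncertainty. Compound 4 is expected to give about 24000 nM in this assay, within a range of 9000 nM to 60000 nM.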

Compound 4, half-maximal inhibitory concentration: 7270 nM
Compound 4: middle estimate off by 3.3-fold (0.52 log units), on the high side; the whole stated range lies above it.
By their numbers in this assay, from the lowest: compound 4; then compound 2; then compounds 1 and 3 (each within the scatter of the next).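

In this assay, among these compounds, bromo in place of hydrogen, on the aromatic carbon ortho to a hydroxy group and ortho to a methoxymethyl group, gives the first measured reading for this position (a 4.9-fold lower number from compound 3 to compound 4 (0.69 log units; beyond the scatter)), and it exceeds the scatter. With both bromo groups present, the side group also matters: methyl in place of hydrogen on the oxygen gives (a 2.1-fold lower number from compound 2 to compound 4 (0.31 log units; beyond the scatter)), and methoxymethyl in place of formyl gives (a 4.3-fold lower number from compound 1 to compound 4 (0.63 log units; beyond the scatter)), making compound 4 the lowest of the four. No measurement available here accounts for either change.

On these data alone, whether bromo at this position gives a similar step alongside a hydroxymethyl or formyl group remains open. So does the outcome with chloro at this position, or with a longer ether chain, an amine or a carboxylic acid in place of methoxymethyl.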